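A few compounds are considered here, and "the series" means these few. Any claim that something is new, unique, unknown or untested is made for them only; others in the source may bear on it.

Measured so far:
- compound 1, `C[C@H](Nc1nc2cc(Cl)c(F)cc2s1)c1ccccc1`, gives 58900 nM in a functional assay on HeLa cells (Homo sapiens) for cytotoxicity, read by MTT assay, with a stated time of 24 h; on this read-out lower numbers stand for stronger inhibition and higher numbers for weaker inhibition
- compound 2, `C[C@H](Nc1nc2cc(Cl)c(F)cc2s1)c1ccc(F)cc1`, gives 61900 nM in this assay

Going by the values given here, compound 2 sits alongside compound 1, and the single step between them, a 1.1-fold higher number from compound 1 to compound 2 (0.02 log units; within the scatter), keeps both numbers within the scatter of each other. Compound 3, `C[C@H](Nc1nc2cc(Cl)c(F)cc2s1)C1CCCCC1`, differs from compound 2 by cyclohexyl in place of 4-fluorophenyl on a saturated chain carbon bound to a nitrogen on an aromatic ring and a saturated chain carbon. Among the compounds with values here, no measured step swaps an aromatic ring for a saturated one, so the one known step bears only loosely on this change and suggests little movement. Compound 3 is expected to give 70000 nM in this assay, within 25000 nM to 200000 nM, which would mean an estimated step of a 1.1-fold higher number from compound 2 to compound 3 (0.05 log units; within the scatter).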

Compound 3, half-maximal inhibitory concentration: 72500 nM
Compound 3: the middle estimate sits 1.0-fold (0.02 log units) below what was measured; the measured number falls inside the stated range.
By their numbers in this assay, from the lowest: compounds 1, 2 and 3 (each within the scatter of the next).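

Swapping the whole ring at this position changes little: the earlier compounds varied only a single fluoro, whereas here cyclohexyl replaces an aromatic ring, and in this assay both a 1.2-fold higher number from compound 2 to compound 3 (0.07 log units; within the scatter) and a 1.2-fold higher number from compound 1 to compound 3 (0.09 log units; within the scatter) stay within the scatter. Among these three compounds, then, an aromatic ring on the saturated chain carbon is not needed to keep the number where it is. No measurement offered here explains this result.

The compounds shown leave open what an amine or a carboxylic acid on this ring would do. They also leave open whether a longer open chain could stand in place of the ring.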